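Fluoro for hydrogen on the pendant phenyl of compound 1

This account rests on a few compounds, and the source may have more. Where it says the series, first, only, none or still open, it means among the compounds named here.

Two members of this series have numbers in a functional assay on HL-60 cells (Homo sapiens) for inhibition, read by MTT assay, with a stated time of 72 h (on this read-out lower numbers stand for stronger inhibition and higher numbers for weaker inhibition), so far. Compound 1 `COc1cc(OC)cc(N2CCN(C(=O)c3onc(C)c3-c3ccccc3)CC2)c1` gives 152 nM in this assay. Compound 2 `COc1cccc(N2CCN(C(=O)c3oc(C)nc3-c3ccc(F)cc3)CC2)c1` differs from compound 1 in several places. In this assay compound 2 gives 112 nM. These two numbers lie within the scatter of one another, so neither compound stands apart from the other on what is known; compound 1 simply has the higher of the two values without that gap meaning anything.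

The next compound, compound 3 `COc1cc(OC)cc(N2CCN(C(=O)c3onc(C)c3-c3ccc(F)cc3)CC2)c1`, keeps the whole of compound 1 except for one change: fluoro in place of hydrogen on an aromatic carbon. Going by the values given here, no step between two measured compounds isolates a change of this kind, so there is nothing itself to calibrate against.

With a single fluorine entering, no ring, no donor or acceptor added, a small effect is the default expectation. The step from compound 1 to compound 3 in this assay is expected to be a 1.2-fold lower number from compound 1 to compound 3 (0.07 log units; within the scatter), that is, no change beyond the scatter in either direction. Compound 3 is accordingly estimated at 130 nM in this assay, with a range from 55 nM to 310 nM.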

Compound 3, half-maximal inhibitory concentration: 475 nM
The estimate for compound 3 lay 3.7-fold (0.56 log units) below the measured number, outside the stated range (above it).
By their numbers in this assay, from the lowest: compounds 2 and 1 (each within the scatter of the next); then compound 3.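

In this assay the change from phenyl to 4-fluorophenyl brings a 3.1-fold higher number from compound 1 to compound 3 (0.49 log units; beyond the scatter) and so moves the number beyond the scatter, towards weaker inhibition, although only one heavy atom enters and no ring, donor, acceptor or charge comes with it. Going by these compounds alone, this is the first step that isolates a single change, and it shows that this aromatic carbon, para to a large group, is not indifferent to substitution on the core of compound 1, which the earlier pair, differing in several places, could not show. Nothing at hand bears on what lies behind this step, so it stands as an observation only.

Going by these compounds, whether the loss is particular to fluoro or extends to other groups at this carbon stays open, and a methoxy group, an amine or a carboxylic acid in the same place would help to separate these readings. Compound 2 also carries a 4-fluorophenyl group, but it has no unsubstituted partner here, so whether the step carries over to its core cannot be read.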